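Thiocarbonyl to carbamoyl on the thioether sulfur

A few compounds are considered here, and "the series" means these few. Any claim that something is new, unique, unknown or untested is made for them only; others in the source may bear on it.

Working notes on the series. Compound 3 `CCCC(=S)SCC(=O)c1ccc(OC)cc1` gives the lowest number of the three measured in an assay on HEK293 cells for inhibition of protein deacetylase HDAC6 (Homo sapiens) (on this read-out lower numbers stand for stronger inhibition and higher numbers for weaker inhibition), with 110 nM. Compound 1 `COCCSC(=S)SCC(=O)c1ccc(OC)cc1` gives 2130 nM in this assay, and compound 2 `CCOC(=O)SCC(=O)c1ccc(OC)cc1` gives 5360 nM.

Compound 4 `CCNC(=O)SCC(=O)c1ccc(OC)cc1` is not yet measured. It differs from compound 3 by a group of 5 heavy atoms (3 carbon, 1 nitrogen, 1 oxygen; no ring) in place of a group of 5 heavy atoms (4 carbon, 1 sulfur; no ring), on a sulfur, the entering group being an ethylcarbamoyl.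

For the measured compounds named here, two measured steps bear on this change, both moving toward compound 3. The step of a 19-fold lower number from compound 1 to compound 3 (1.29 log units; beyond the scatter) shows a propyl on the thiocarbonyl carbon far ahead of a (2-methoxyethyl)sulfanyl. The step of a 49-fold lower number from compound 2 to compound 3 (1.69 log units; beyond the scatter) shows the same sulfur carrying a group with thiocarbonyl and four carbons far ahead of a group with a carbonyl and two oxygens. Compound 4 keeps the carbonyl arrangement of compound 2 and adds a hydrogen-bond donor, so the step from compound 3 is expected to run in the same direction as the reverse of compound 2 to compound 3, that is toward a larger number and beyond the scatter, roughly a 27-fold higher number from compound 3 to compound 4 (1.44 log units; beyond the scatter).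

For compound 4 the estimated value in this assay is 3000 nM, with a range from 800 nM to 12000 nM.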

Compound 4, half-maximal inhibitory concentration: 132 nM
Beside the measured number, compound 4's estimate is 23-fold (1.36 log units) above it; measured number outside the range, below it.
By their numbers in this assay, from the lowest: compounds 3 and 4 (each within the scatter of the next); then compound 1; then compound 2.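

In this assay, putting ethylcarbamoyl on the sulfur in place of the thiocarbonyl group of compound 3 gives a 1.2-fold higher number from compound 3 to compound 4 (0.08 log units; within the scatter) and so leaves the two compounds indistinguishable, which shows that a thiocarbonyl is not required on this sulfur for a value in this range. Compound 2 and compound 4 both carry the carbonyl. With the carbonyl kept, ethylamino in place of ethoxy on the carbonyl carbon gives a 41-fold lower number from compound 2 to compound 4 (1.61 log units; beyond the scatter) in this assay and marks the atom attached to that carbon as a sensitive point in this series. No measurement on hand accounts for the size of this step.

From the compounds shown here alone, whether the amide hydrogen matters stays open, and a dimethylamino group on the carbonyl carbon would bear on that question. Also open, going by these compounds, is how far the ethyl of the ethylcarbamoyl can change, for example to a longer chain or to a piperidine ring, and whether an ethylamino group on a thiocarbonyl carbon would behave as it does on the carbonyl carbon.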